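Swapping the aryl group on compound 1's ring nitrogen

The source may report more compounds than this note shows. Statements on the series, on what has been measured and on what is new or still open speak of the compounds shown alone.

In an assay on HEK293 cells for displacement of a labelled ligand from growth hormone secretagogue receptor type 1 (Homo sapiens), with a stated time of 60 min (on this read-out lower numbers stand for stronger inhibition and higher numbers for weaker inhibition), compound 1 `Cc1ncccc1-c1nc2cn(-c3cccc(OC(C)C)c3)nc2c(=O)n1C[C@H]1CCCN(C[C@H]2CCCO2)C1` gives 11 nM. Among the three measured compounds it stands second highest: compound 3 `CCO[C@H](C)CN1CCC[C@H](Cn2c(-c3cccnc3C)nc3cn(-c4cccc(OC)c4)nc3c2=O)C1` gives 40 nM, a higher number, while compound 2 `COc1cccc(-n2cc3nc(-c4cccnc4C)n(C[C@H]4CCCN(Cc5ccco5)C4)c(=O)c3n2)c1` gives 2.7 nM, the lowest number of the set.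

Going by the values given here, the only measured step between compounds that differ in a single place is a 15-fold higher number from compound 2 to compound 3 (1.17 log units; beyond the scatter). That step concerns the group attached to the amine nitrogen in the saturated ring and says nothing directly about the aryl group on the aromatic nitrogen.

Compound 4 `COc1ccc(-n2cc3nc(-c4cccnc4C)n(C[C@H]4CCCN(C[C@H]5CCCO5)C4)c(=O)c3n2)cc1` differs from compound 1 in exactly that aryl group: 4-methoxyphenyl in place of 3-isopropoxyphenyl on an aromatic nitrogen. Compounds 2 and 3 both carry a methoxyphenyl at the same place, but each also differs from compound 1 in the amine substituent, so no single-change comparison is available. Without a directly relevant step, a change in either direction that stays near the scatter is the most reasonable expectation, with a wide range to reflect the uncertainty. Compound 4 is therefore expected to give about 15 nM, between 4 nM and 60 nM, which corresponds to an expected step of a 1.4-fold higher number from compound 1 to compound 4 (0.13 log units; within the scatter).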

Compound 4, half-maximal inhibitory concentration in the growth hormone secretagogue receptor type 1 assay: 52 nM
For compound 4 the middle estimate is 3.5-fold (0.54 log units) below the measured one; the range from low to high includes it.
By their numbers in the growth hormone secretagogue receptor type 1 assay, from the lowest: compound 2; then compound 1; then compounds 3 and 4 (each within the scatter of the next).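

Going by these compounds alone, in the growth hormone secretagogue receptor type 1 assay, the aryl group on this aromatic nitrogen clearly matters, which the earlier compounds could not show: putting 4-methoxyphenyl in place of 3-isopropoxyphenyl gives a 4.7-fold higher number from compound 1 to compound 4 (0.67 log units; beyond the scatter). In a physicochemical assay for lipophilicity, using the shake flask method, measured as octanol-water partition, with a stated time of 30 min, at pH 7.4 (on this read-out higher numbers stand for higher lipophilicity and lower numbers for lower lipophilicity), compound 1 gives 2.7 and compound 4 gives 1.9. The same swap therefore also lowers lipophilicity, so in this single pair the higher binding number comes with lower lipophilicity, although one pair cannot show that the two are linked: the measured distribution coefficient of compound 1, 2.7, and of compound 4, 1.9, a number 0.80 log units lower (beyond the scatter)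

Compound 4 changes two things at once, the ether group from isopropoxy to methoxy and its place on the phenyl ring, and the compounds shown do not separate these two changes. As far as these compounds go, how an unsubstituted phenyl or a pyridine ring would behave on this nitrogen also remains open, for both binding and lipophilicity.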